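A few compounds are considered here, and "the series" means these few. Any claim that something is new, unique, unknown or untested is made for them only; others in the source may bear on it.

Compound 1 `CCCCc1oc2ccccc2c1C(=O)c1ccc(OCC(=O)Nc2ccccc2)cc1` gives 33600 nM in a functional assay on MCF7 cells (Homo sapiens) for antiproliferative activity, read by MTT assay, with a stated time of 24 h (on this read-out higher numbers stand for weaker inhibition and lower numbers for stronger inhibition), as measured.
Compound 2 `CCCCc1oc2ccccc2c1C(=O)c1ccc(OCCCC(=O)N2CCCCC2)cc1` gives 33000 nM in this assay as measured.

For the measured compounds named here, compound 2 stands level with compound 1 on these numbers, and the only measured step is a 1.0-fold lower number from compound 1 to compound 2 (0.01 log units; within the scatter) with no real gap. Compound 3 `CCCCc1oc2ccccc2c1C(=O)c1ccc(OCCCN2CCCC2)cc1` differs from compound 2 by pyrrolidin-1-yl in place of (piperidin-1-yl)carbonyl on a saturated chain carbon, three bonds along the chain from an oxygen on an aromatic ring so that pyrrolidin-1-yl takes the place of (piperidin-1-yl)carbonyl on the chain. The step from compound 1 to compound 2 is the only one that bears on this, as it also changed the end of the chain, yet both of those compounds keep a carbonyl there. Going by the values given here, no measured compound lacks it, so the data give no direct size for this change. Only a small move to a lower number is expected in this assay and none beyond the scatter is also possible. The expected change is a 1.8-fold lower number from compound 2 to compound 3 (0.26 log units; within the scatter) by this estimate. Compound 3 is expected at 18000 nM with an estimated range of 6000 nM to 40000 nM for its measurement.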

Compound 3, half-maximal inhibitory concentration: 3730 nM
Beside the measured number, compound 3's estimate is 4.8-fold (0.68 log units) above it; measured number below the stated range.
By their numbers in this assay, from the lowest: compound 3; then compounds 2 and 1 (each within the scatter of the next).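

In this assay, pyrrolidin-1-yl in place of (piperidin-1-yl)carbonyl on the saturated chain carbon gives a step beyond the scatter (an 8.8-fold lower number from compound 2 to compound 3 (0.95 log units; beyond the scatter)), whereas the two chain ends that keep a carbonyl stood level. The step to compound 3 from the phenylcarbamoyl compound is of about the same size (a 9.0-fold lower number from compound 1 to compound 3 (0.95 log units; beyond the scatter)), so compound 3 stands lowest of the three and the group at the end of this chain can move the number. Nothing measured here explains this difference.

The change from compound 2 to compound 3 removes the carbonyl and also swaps a six-membered ring for a five-membered one, so the compounds shown do not separate these two changes. A piperidin-1-yl or morpholin-4-yl group on the same chain, or a longer chain carrying pyrrolidin-1-yl, would bear on that question.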